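Losing the Benzoyl Group from Compound 1

This account rests on a few compounds, and the source may have more. Where it says the series, first, only, none or still open, it means among the compounds named here.

Measured in a functional assay for inhibition, with Homo sapiens as the target; on this read-out higher numbers stand for weaker inhibition and lower numbers for stronger inhibition:
- compound 1 `Cc1cc2c(cc1C(=O)N=C(N)N)S(=O)(=O)CC2(O)C(=O)c1ccccc1`: 157 nM
- compound 2 `COC1c2cc(C)c(C(=O)N=C(N)N)cc2S(=O)(=O)C1(C)C`: 138 nM

Compound 1, at 157 nM, stands level with compound 2, at 138 nM, the two values lying within the scatter of each other. Compound 3 `Cc1cc2c(cc1C(=O)N=C(N)N)S(=O)(=O)CC2O` has not yet been measured. It carries hydrogen in place of benzoyl on a saturated ring carbon of compound 1 (hydrogen in place of benzoyl on a saturated ring carbon). Among the measured compounds shown here, no measured pair differs in one place, so the data offer no direct guide to this change. In this assay, a moderate step towards a higher number, meaning weaker inhibition, is expected, though with wide uncertainty. The expected change is a 2.5-fold higher number from compound 1 to compound 3 (0.41 log units; beyond the scatter). The estimated value for compound 3 is 400 nM, within a range of 100 nM to 1800 nM.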

Compound 3, half-maximal inhibitory concentration: 1050 nM
The estimate for compound 3 lay 2.6-fold (0.42 log units) below the measured number, and the stated range covers the measured number.
By their numbers in this assay, from the lowest: compounds 2 and 1 (each within the scatter of the next); then compound 3.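

In this assay putting hydrogen in place of benzoyl on this saturated ring carbon gives a 6.7-fold higher number from compound 1 to compound 3 (0.83 log units; beyond the scatter) and so shows that the number at this position depends on what the carbon carries. Among these two compounds, the stronger inhibition goes with the benzoyl group of compound 1. Nothing measured here explains this step. The compounds shown leave open which part of benzoyl matters. An acetyl group or a benzyl group on the same carbon would separate the contribution of the carbonyl from that of the aromatic ring.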